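The source may hold more compounds than are shown below. What is called first, only, known or untested is meant among the compounds shown, and "the series" means these compounds.

Working notes on the series. Of the compounds shown here, three have been measured: compound 1 `O=C(O)Cc1sc(C(c2ccc(F)cc2)c2ccc(F)cc2)nc1-c1ccco1`, compound 2 `NS(=O)(=O)c1ccc(-c2nc(C(c3ccc(F)cc3)c3ccc(F)cc3)sc2CC(=O)O)cc1` and compound 3 `O=C(O)Cc1sc(C(c2ccc(F)cc2)c2ccc(F)cc2)nc1-c1cc(F)nc(F)c1`. They share one core and differ only in the aromatic group attached to it. In an in vitro functional assay on HEK285-7 cells for antagonist activity at prostaglandin D2 receptor 2 (Homo sapiens), read by BRET and beta-arrestin recruitment (on this read-out lower numbers stand for smaller maximal responses and higher numbers for larger maximal responses), compound 1 gives 80%. In this assay compound 2 gives 80%. In this assay compound 3 gives 80%. Compound 3 therefore stands level with compounds 1 and 2; its nearest neighbour on the numbers is compound 1 and its furthest is compound 2, and even that gap lies within the scatter.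

Every single-point exchange measured so far concerns the same aromatic carbon of the core, and each was flat: no change at the digits printed from compound 1 to compound 2 (within the scatter); no change at the digits printed from compound 1 to compound 3 (within the scatter); no change at the digits printed from compound 2 to compound 3 (within the scatter).

The next compound is compound 4 `CS(=O)(=O)Nc1cccc(-c2nc(C(c3ccc(F)cc3)c3ccc(F)cc3)sc2CC(=O)O)c1`. Its change from compound 3 is 3-(methanesulfonamido)phenyl in place of 2,6-difluoropyridin-4-yl on an aromatic carbon. All three measured exchanges at this position bear on it directly, and none moved the maximal response beyond the scatter, so the expectation for this assay is a step of no size beyond the scatter, in no particular direction; the expected step is no change at the digits printed from compound 3 to compound 4 (within the scatter). Compound 4 is accordingly estimated at 80%, with an expected range from 68% to 92%.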

Compound 4, largest response reached (reported as efficacy), in percent of the reference or control that the assay uses: 80%
For compound 4 middle estimate and measured number coincide at the digits printed; the range from low to high includes it.
By their numbers in this assay, from the lowest: compounds 1, 2, 3 and 4 (each within the scatter of the next).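

In this assay, the position on the aromatic carbon next to the ring nitrogen accepts 3-(methanesulfonamido)phenyl, with 11 heavy atoms and 1 hydrogen-bond donor, in place of 2,6-difluoropyridin-4-yl, with 8 heavy atoms and no donor, and the exchange gives no change at the digits printed from compound 3 to compound 4 (within the scatter). The comparisons with the other two aromatic groups read the same way, with no change at the digits printed from compound 2 to compound 4 (within the scatter) against 4-sulfamoylphenyl and no change at the digits printed from compound 1 to compound 4 (within the scatter) against furan-2-yl, so the flat picture at this position now extends to a methanesulfonamido group on a phenyl ring. No supporting data are available to explain this flatness.

All four compounds carry an aromatic ring at this position, so the compounds shown leave open whether a non-aromatic group, such as an aliphatic amine or a short alkyl chain, or a bare hydrogen would hold the maximal response in this assay. They also leave open whether the maximal response responds at all to exchanges elsewhere on the shared core, such as replacing the carboxymethyl group with a longer chain bearing the carboxylic acid.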